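Cytotoxicity notes on compounds 1, 2 and 3

The source may hold more compounds than are shown below. What is called first, only, known or untested is meant among the compounds shown, and "the series" means these compounds.

In an ADME assay on PC-3 cells (Homo sapiens) for cytotoxicity, read by WST assay, tested at 100 uM (a lower number here means less inhibition, a higher number more inhibition at the concentration tested (going by the name of the read-out)), compound 1 `CSc1cccc(C(=O)N2CCCC(C(=O)Nc3ccc(Cl)cc3)C2)c1` gives 0%. Among the measured compounds shown here, compound 2 `Cn1cnnc1-c1cccc(NC(=O)C2CCCN(C(=O)c3cc(C(F)(F)F)cc(C(F)(F)F)c3)C2)c1` gives 0% in this assay, and the two values are level within the scatter, so compound 1 stands no different from compound 2 on the numbers so far. Compound 3 `CC(C)(C)CC(=O)Nc1cccc(C(=O)N2CCCC(C(=O)Nc3ccc(Cl)cc3)C2)c1` is the next to be run in this assay. It differs from compound 1 by (neopentylcarbonyl)amino in place of methylsulfanyl on an aromatic carbon. For the measured compounds named here, no step between measured compounds is known, and with both measured values flat, a move beyond the scatter is not expected from this change. Compound 3 is expected to give 3%, with a range of 0% to 15%. The expected step of a number 3 percentage points higher from compound 1 to compound 3 (within the scatter) lies within the scatter.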

Compound 3, a percentage reported as inhibition, at one concentration (the size of the read-out at that concentration, not a potency): 0%
Compound 3: the middle estimate sits 3 percentage points above what was measured; the measured number falls inside the stated range.
By their numbers in this assay, from the lowest: compounds 1, 2 and 3 (each within the scatter of the next).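

In this assay, (neopentylcarbonyl)amino in place of methylsulfanyl gives no change at the digits printed from compound 1 to compound 3 (within the scatter). This aromatic carbon, meta to a large group, therefore accepts a much larger substituent, one that adds a hydrogen-bond donor, with no shift in the read-out beyond the scatter. No measurement offered here accounts for this flat result.

On these data alone, what a carboxylic acid or an amine on this aromatic carbon would give stays open. As far as these compounds go, whether any change at this position can raise the inhibition reading also remains unknown.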